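The compounds below may be only part of what the source reports. "The series", "measured", "known", "first", "only" and "open" are said of these compounds alone.

Three compounds in the series share a core and differ only at the terminal end of the acrylamide chain: compound 1 `CC/C=C/C(=O)Nc1cc2c(N3CCc4ccccc43)ncnc2cc1OC`, compound 2 `CCN(CC)C/C=C/C(=O)Nc1cc2c(N3CCc4ccccc43)ncnc2cc1OC` and compound 3 `COc1cc2ncnc(N3CCc4ccccc43)c2cc1NC(=O)/C=C/CN1CCCCC1`. In a functional assay on PC-3 cells (Homo sapiens) for antiproliferative activity, read by MTT assay, with a stated time of 72 h (a lower number here means a stronger inhibitor, a higher number a weaker inhibitor), compound 1 gives 5890 nM, compound 2 gives 3690 nM, and compound 3 gives 4180 nM. On these numbers compound 3 sits between the other two, with a 1.1-fold higher number from compound 2 to compound 3 (0.05 log units; within the scatter) and a 1.4-fold lower number from compound 1 to compound 3 (0.15 log units; within the scatter); neither step stands out of the scatter. Compound 4 `COc1cc2ncnc(N3CCc4ccccc43)c2cc1NC(=O)/C=C/CN1CCC(CO)CC1` is reached from compound 3 by hydroxymethyl in place of hydrogen on a saturated ring carbon. Among the measured compounds shown here, no measured step probes a substituent on this ring, so the expectation rests on the flat profile across compounds 1 to 3. The step from compound 3 to compound 4 in this assay is estimated as a 1.0-fold higher number from compound 3 to compound 4 (0.00 log units; within the scatter), none beyond the scatter. Compound 4 is therefore expected near 4200 nM, within 2000 nM to 9000 nM.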

Compound 4, half-maximal inhibitory concentration: 2650 nM
Estimate against measurement, compound 4: 1.6-fold (0.20 log units) above; measured number inside the range.
By their numbers in this assay, from the lowest: compounds 4, 2, 3 and 1 (each within the scatter of the next, the first and the last beyond it).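

Hydroxymethyl on a saturated ring carbon of the piperidin-1-yl group leaves activity in this assay within the scatter (a 1.6-fold lower number from compound 3 to compound 4 (0.20 log units; within the scatter)), and the same holds against diethylamino (a 1.4-fold lower number from compound 2 to compound 4 (0.14 log units; within the scatter)). Only 4-(hydroxymethyl)piperidin-1-yl in place of methyl gives a step beyond the scatter (a 2.2-fold lower number from compound 1 to compound 4 (0.35 log units; beyond the scatter)), which neither diethylamino nor piperidin-1-yl reached. Nothing measured here bears on the reason for these steps.

Going by these compounds, whether an amine, a carboxylic acid or a longer hydroxyalkyl chain on this ring carbon would behave like hydroxymethyl remains open.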